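Benzylamine head-group variants on the shared core

The source may hold more compounds than are shown below. What is called first, only, known or untested is meant among the compounds shown, and "the series" means these compounds.

compound 1 `CCC[C@@H](CCO)Nc1nc(N)nc(C)c1Cc1ccc(CNC2CN(C)C2)cc1OC` — limit of the assay only: > 10000 nM
compound 2 `CCC[C@@H](CCO)Nc1nc(N)nc(C)c1Cc1ccc(CN(C)CC(N)=O)cc1OC` — limit of the assay only: > 10000 nM

In an assay on HEK293 cells for agonist activity at Toll-like receptor 8 (Homo sapiens) (a higher number here means that more compound is needed for the effect, a lower number that less compound is needed), compound 2 stands at the limit of the assay, > 10000 nM, and no number is available for it. The measured step that the two limits leave unreadable from compound 1 to compound 2 is accordingly unreadable, as both values sit at the limit (the limit of > 10000 nM in this assay, at which 2 of the 2 values shown sit). Compound 3 `CCC[C@@H](CCO)Nc1nc(N)nc(C)c1Cc1ccc(CNC2CNC2)cc1OC` carries (azetidin-3-yl)amino in place of (carbamoylmethyl)(methyl)amino on a saturated chain carbon bound to an aromatic carbon. Within the data shown here, the only measured step bearing on this position gives no size, so nothing points to a readable gain. Compound 3 is therefore expected to remain at the limit, with an estimate of 15000 nM (range 5000 nM to 50000 nM). The expected step is then a step that the limit leaves unreadable from compound 2 to compound 3, no readable change.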

Compound 3, half-maximal effective concentration: > 10000 nM
Compound 3: no number, only a limit; the forecaster's own chance of this, stated with the estimate: 85%; the middle value does not contradict the limit.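

No step can be read among compound 1, compound 2 and compound 3, because each gives only a limit: the limit of > 10000 nM in this assay, at which 3 of the 3 values shown sit.
The compounds shown leave open whether any head-group gives a readable value in this assay on the shared core.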